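Shortening the oxime chain on compound 3

The compounds below may be only part of what the source reports. "The series", "measured", "known", "first", "only" and "open" are said of these compounds alone.

Compound 3 `CCO/N=C(\C)c1ccccc1NCC1=NCCN1` belongs to a set of three compounds with a shared core, all examined in a functional assay for activation of Alpha-1B adrenergic receptor (Homo sapiens), read by calcium flux; a higher number here means that more compound is needed for the effect, a lower number that less compound is needed. In this assay compound 3 gives < 5020 nM, which is a limit of the assay rather than a number. Compound 1 `Cc1ncc(-c2ccccc2NCC2=NCCN2)o1` gives < 5020 nM, likewise a limit. Compound 2 `Cc1ccsc1-c1ccccc1NCC1=NCCN1` gives 112 nM in this assay. Compound 3 therefore stands at the limit where two of the three values sit (the limit of < 5020 nM in this assay, at which 2 of the 3 values shown sit), and its place relative to compound 2 cannot be read from what is known.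

Compound 4 `CO/N=C/c1ccccc1NCC1=NCCN1` differs from compound 3 in a single place: a group of 4 heavy atoms (2 carbon, 1 nitrogen, 1 oxygen; no ring) in place of a group of 6 heavy atoms (4 carbon, 1 nitrogen, 1 oxygen; no ring), on an aromatic carbon. The measured steps that reach compound 3 are a step that the two limits leave unreadable from compound 1 to compound 3 and a step that the limit leaves unreadable from compound 2 to compound 3, and neither has a readable size, since a limit sits at one or both ends. For the measured compounds named here, no measured step therefore tells how a change at this position moves the read-out, and with compound 3 itself known only as a limit, neither the direction nor the size of the step to compound 4 can be drawn from the measured steps.

Compound 4 is expected to give about 1500 nM in this assay, with a range from 200 nM to 5000 nM. The step this estimate implies is a step that the limit leaves unreadable from compound 3 to compound 4, offered as a loose expectation only.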

Compound 4, half-maximal effective concentration: < 5020 nM
Compound 4: only a limit was reported; the forecaster's own chance of this, stated with the estimate: 40%; the middle value is on the limit's open side.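

In this assay compound 4 gives < 5020 nM, which is a limit of the assay and not a number. No step from compound 1, compound 2 or compound 3 to compound 4 can be read, since a limit stands at one or both ends of each: the limit of < 5020 nM in this assay, at which 3 of the 4 values shown sit.

The compounds shown leave open whether changing the chain between compound 3 and compound 4 moves the read-out at all.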